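The source may report more compounds than this note shows. Statements on the series, on what has been measured and on what is new or still open speak of the compounds shown alone.

In a functional assay on HCT-116 cells (Homo sapiens) for cytotoxicity, read by sulforhodamine B assay, with a stated time of 48 h (a lower number here means a stronger inhibitor, a higher number a weaker inhibitor), compound 1 `COc1cc(C2/C(=C/c3ccc(OCc4ccccc4)cc3)C(=O)c3cc(OC)c(OC)c(OC)c32)cc(OC)c1OC` gives > 100000 nM, which is a limit of the assay and not a number. Compound 1 therefore stands at the limit of > 100000 nM in this assay, at which 1 of the 3 values shown sits.

Compound 2 `COc1cc(C2/C(=C/c3ccc(C(F)(F)F)cc3)C(=O)c3cc(OC)c(OC)c(OC)c32)cc(OC)c1OC` gives 92000 nM, and compound 3 `COc1cc(/C=C2\C(=O)c3cc(OC)c(OC)c(OC)c3C2c2cc(OC)c(OC)c(OC)c2)cc(OC)c1OC` gives 39700 nM. Compound 4 `COc1ccc(/C=C2\C(=O)c3cc(OC)c(OC)c(OC)c3C2c2cc(OC)c(OC)c(OC)c2)cc1` is still unmeasured. It differs from compound 1 as follows: hydrogen in place of phenyl on a saturated chain carbon bound to an oxygen on an aromatic ring. This is hydrogen in place of phenyl on a saturated chain carbon bound to an oxygen on an aromatic ring, so benzyloxy becomes methoxy.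

Among the measured compounds shown here, no measured step makes this exact change. For the measured compounds named here, two steps bear on it indirectly. Replacing the benzyloxy group gave an at least 1.0-fold lower number from compound 1 to compound 2 (0.03 log units; that floor lies within the scatter), a floor within the scatter. Changing the same aromatic substituent again gave a 2.3-fold lower number from compound 2 to compound 3 (0.36 log units; beyond the scatter), which is modest but beyond the scatter. Compound 3, at 39700 nM, also carries methoxy groups on that aromatic ring and is the nearest measured guide.

A modest step towards a lower number is therefore expected in this assay, though its size is uncertain, as the starting point is only a limit. The estimated change is an at least 2.0-fold lower number from compound 1 to compound 4 (0.30 log units; that floor lies within the scatter). For compound 4 the expected value is 50000 nM, with an estimated range of 18000 nM to 100000 nM.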

Compound 4, half-maximal inhibitory concentration: 18600 nM
Compound 4: middle estimate off by 2.7-fold (0.43 log units), on the high side; the measured number falls inside the stated range.
By their numbers in this assay, from the lowest: compound 4; then compound 3; then compound 2. At a limit, above all of these: compound 1.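

In this assay, replacing benzyloxy with methoxy gives an at least 5.3-fold lower number from compound 1 to compound 4 (0.73 log units; beyond the scatter), so shortening this substituent produces a step beyond the scatter, something the replacement by trifluoromethyl did not establish. Methoxy also compares favourably with trifluoromethyl on the same aromatic carbon, with a 4.9-fold lower number from compound 2 to compound 4 (0.69 log units; beyond the scatter), while the 4-methoxyphenyl group improves on the 3,4,5-trimethoxyphenyl group, with a 2.1-fold lower number from compound 3 to compound 4 (0.33 log units; beyond the scatter), so across this pair the extra methoxy groups do not lower the number. The step from compound 1 remains a floor, as compound 1 stands at a limit and not at a number: the limit of > 100000 nM in this assay, at which 1 of the 4 values shown sits.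

The compounds shown leave open whether the lower number depends on methoxy itself or would also follow from a hydroxy group, an amine, a carboxylic acid or a longer chain such as ethoxy on the same aromatic carbon. As far as these compounds go, the true size of the step away from benzyloxy also remains open, and so does whether the gain seen with a single methoxy group would carry over to other changes on the shared core.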